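Sulfonyl group exchange from compound 1: working notes

A few compounds are considered here, and "the series" means these few. Any claim that something is new, unique, unknown or untested is made for them only; others in the source may bear on it.

In an ADME assay on microsomes from liver (Homo sapiens) for metabolic stability, read by LC-MS, using NADPH, with a stated time of 60 min, tested at 1 uM (a higher number here means faster removal of the compound, a lower number slower removal), compound 1 `CNC(=O)c1cc(S(=O)(=O)N2CCS[C@H]2C(=O)O[C@@H](Cc2c(Cl)c[n+]([O-])cc2Cl)c2ccc(OC(F)F)c(OCC3CC3)c2)cn1C` gives 202 mL.min-1.g-1 while compound 2 `CN(C)C(=O)c1cccc(S(=O)(=O)N2CSC[C@H]2C(=O)O[C@@H](Cc2c(Cl)c[n+]([O-])cc2Cl)c2ccc(OC(F)F)c(OCC3CC3)c2)c1` gives 268 mL.min-1.g-1 and compound 3 `CN(C)C(=O)c1cccc(S(=O)(=O)N2CCCC[C@H]2C(=O)O[C@@H](Cc2c(Cl)c[n+]([O-])cc2Cl)c2ccc(OC(F)F)c(OCC3CC3)c2)c1` gives 363 mL.min-1.g-1 with all three values within the scatter of each other. Compound 1 therefore has no distinct standing in this small set, and all three numbers sit in one band.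

The change to compound 4 `COc1ccc(S(=O)(=O)N2CCS[C@H]2C(=O)O[C@@H](Cc2c(Cl)c[n+]([O-])cc2Cl)c2ccc(OC(F)F)c(OCC3CC3)c2)cc1OC` is a group of 10 heavy atoms (8 carbon, 2 oxygen; one six-membered aromatic ring of carbon only) in place of a group of 10 heavy atoms (7 carbon, 2 nitrogen, 1 oxygen; one five-membered aromatic ring with 1 hetero atom), on a sulfonyl sulfur and the entering group is 3,4-dimethoxyphenyl, on a sulfonyl sulfur. The core of compound 1 stays as it is.

Among the measured compounds shown here, no measured step covers this change, so the expectation rests only on the band running from compound 1 at 202 mL.min-1.g-1 to compound 3 at 363 mL.min-1.g-1 and nothing more specific. In this assay the expected step is a 1.5-fold higher number from compound 1 to compound 4 (0.17 log units; within the scatter) which leans toward faster removal and is not expected to pass beyond the scatter. For compound 4 the estimated value is 300 mL.min-1.g-1 with an expected range from 150 mL.min-1.g-1 to 600 mL.min-1.g-1 as working figures.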

Compound 4, intrinsic clearance in microsomes: 200 mL.min-1.g-1
Compound 4: middle estimate off by 1.5-fold (0.18 log units), on the high side, and the stated range covers the measured number.
By their numbers in this assay, from the lowest: compounds 4, 1, 2 and 3 (each within the scatter of the next).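

In this assay, among the compounds shown here, the entry of 3,4-dimethoxyphenyl on a sulfonyl sulfur gives a 1.0-fold lower number from compound 1 to compound 4 (0.00 log units; within the scatter) and so provides the first step in this set that differs in one place only. With the core of compound 1 unchanged, a six-membered aromatic ring of carbon only can stand here in place of a five-membered aromatic ring with 1 hetero atom, and the hydrogen-bond donor of the leaving group can go, without a step beyond the scatter. Nothing available bears on why the number holds across this exchange.

Going by these compounds, whether an amine or a carboxylic acid in the group on this sulfonyl sulfur would leave the number within the scatter remains open. Also open, on these data alone, is whether 3,4-dimethoxyphenyl would behave the same way on the cores of compound 2 and compound 3.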